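Amide variation from compound 3 to compound 4

This account rests on a few compounds, and the source may have more. Where it says the series, first, only, none or still open, it means among the compounds named here.

Measured so far: compound 1 `CC(C)c1c(C(=O)N(C)Cc2ccccc2)nn(-c2ccc(F)cc2)c1CC[C@@H](O)C[C@@H](O)CC(=O)O` gives 6.2 nM; compound 2 `CC(C)c1c(C(=O)N2CCC[C@H](c3ccccc3)C2)nn(-c2ccc(F)cc2)c1CC[C@@H](O)C[C@@H](O)CC(=O)O` gives 2.1 nM; compound 3 `CC(C)c1c(C(=O)NCC2CCCCC2)nn(-c2ccc(F)cc2)c1OC[C@@H](O)C[C@@H](O)CC(=O)O` gives 17 nM.

In an assay on microsomes from liver for inhibition of 3-hydroxy-3-methylglutaryl-coenzyme A reductase (Rattus norvegicus) (a higher number here means a weaker inhibitor, a lower number a stronger inhibitor), compound 3 stands highest of the three numbers, with compound 1 nearest and compound 2 furthest below it. Compound 4 `CC(C)c1c(C(=O)N2CCCCC2)nn(-c2ccc(F)cc2)c1OC[C@@H](O)C[C@@H](O)CC(=O)O` differs from compound 3 by piperidin-1-yl in place of (cyclohexylmethyl)amino on a carbonyl carbon. Among the measured compounds shown here, the one measured step that bears on this, a 3.0-fold lower number from compound 1 to compound 2 (0.47 log units; beyond the scatter), likewise replaced an open amide substituent with a ring closed through the amide nitrogen and brought a modest lowering; the ring entering here carries no further substituent, so a smaller shift of the same direction is expected, a 1.7-fold lower number from compound 3 to compound 4 (0.23 log units; within the scatter), resting on a 3.0-fold lower number from compound 1 to compound 2 (0.47 log units; beyond the scatter). Compound 4 is estimated at 10 nM, within 4 nM to 25 nM.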

Compound 4, half-maximal inhibitory concentration: 47 nM
Beside the measured number, compound 4's estimate is 4.7-fold (0.67 log units) below it, and the stated range ends below it.
By their numbers in this assay, from the lowest: compound 2; then compound 1; then compound 3; then compound 4.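

In this assay, the change to piperidin-1-yl gives a 2.8-fold higher number from compound 3 to compound 4 (0.44 log units; beyond the scatter), so a ring closed through the amide nitrogen does not by itself lower the number, despite a 3.0-fold lower number from compound 1 to compound 2 (0.47 log units; beyond the scatter). That earlier step kept no amide hydrogen on either side and brought in a phenyl-bearing ring on a different core, whereas this one removes the amide hydrogen and leaves an unsubstituted ring. Nothing available explains the rise.

Still open, as far as these compounds go, is whether the loss of the amide hydrogen or the change in the carbon framework drives the rise. A (cyclohexylmethyl)(methyl)amino group on the same carbonyl carbon would separate the two.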